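Nitrate and furoxan chalcone amides in rat paw edema

The source may report more compounds than this note shows. Statements on the series, on what has been measured and on what is new or still open speak of the compounds shown alone.

Compound 1 `O=C(CO[N+](=O)[O-])Nc1ccc(C(=O)/C=C/c2ccc(Cl)cc2)cc1`: 57%
Compound 2 `COc1ccc(/C=C/C(=O)c2ccc(NC(=O)CO[N+](=O)[O-])cc2)cc1`: 49%
Compound 3 `O=C(COCc1c(-c2ccccc2)no[n+]1[O-])Nc1ccc(C(=O)/C=C/c2ccc(Cl)cc2)cc1`: 48%

Three compounds were tested in a functional assay on the whole organism (strain albino) for inhibition, with Rattus norvegicus as the target, read by paw edema, with stated times of 30 min and 2 h, at a dose of 100 mg/kg by the oral route; a higher number here means more inhibition at the dose given (going by the name of the read-out), a lower number less inhibition. Compound 1 `O=C(CO[N+](=O)[O-])Nc1ccc(C(=O)/C=C/c2ccc(Cl)cc2)cc1` gives 57%, compound 2 `COc1ccc(/C=C/C(=O)c2ccc(NC(=O)CO[N+](=O)[O-])cc2)cc1` gives 49%, and compound 3 `O=C(COCc1c(-c2ccccc2)no[n+]1[O-])Nc1ccc(C(=O)/C=C/c2ccc(Cl)cc2)cc1` gives 48%. The change from compound 1 to compound 2 is methoxy in place of chloro on an aromatic carbon, and it gave a number 8 percentage points lower from compound 1 to compound 2 (within the scatter). The difference between the two cores, that of compound 1 and that of compound 3, is not broken down here. Compound 4 `COc1ccc(/C=C/C(=O)c2ccc(NC(=O)COCc3c(-c4ccccc4)no[n+]3[O-])cc2)cc1` is not yet measured; it differs from compound 3 by methoxy in place of chloro on an aromatic carbon, the same change as from compound 1 to compound 2, which occurs twice among these compounds, at the same place each time. Since that change gave a number 8 percentage points lower from compound 1 to compound 2 (within the scatter), the step from compound 3 to compound 4 in this assay is expected to be of similar size, a number 6 percentage points lower from compound 3 to compound 4 (within the scatter). Compound 4 is therefore estimated at 42%, within 30% to 55%.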

Compound 4, a percentage reported as inhibition, in the whole organism at one dose (the size of the read-out at that dose, not a potency): 42%
Compound 4: the middle estimate sits on the measured number at the digits printed; the measured number falls inside the stated range.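

In this assay, methoxy in place of chloro gave a number 6 percentage points lower from compound 3 to compound 4 (within the scatter), and the change carried across the two cores with much the same size: the same change on two cores in this assay, a number 8 percentage points lower (within the scatter) from compound 1 to compound 2 and a number 6 percentage points lower (within the scatter) from compound 3 to compound 4, 2 percentage points apart, within the scatter of two such steps

Since each step lies within the scatter, the pair shows only that going from 4-chlorophenyl to 4-methoxyphenyl moved the read-out by no more than the scatter on either core, not that methoxy truly lowers inhibition. Two cores at one dose also cannot show that the change would behave alike on any other core or at another dose.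

The compounds shown carry only chloro or methoxy at this place, so it stays open how a fluoro, a nitrile or a dimethylamino group would read there. Also open, from the compounds shown here alone, is how a longer chain would read in place of the link from the amide to the nitrate or furoxan end.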